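Fluorine pattern swap on the aryl tail

The compounds below may be only part of what the source reports. "The series", "measured", "known", "first", "only" and "open" are said of these compounds alone.

The series shares one core: compound 1 `Cc1c(F)cccc1CCCCOc1ccc(/C=C/c2cccc3c(CCCC(=O)O)c(C)n(CC(=O)O)c23)cc1` and compound 2 `Cc1c(CCCC(=O)O)c2cccc(/C=C/c3ccc(OCCCCc4cc(F)c(F)c(F)c4F)cc3)c2n1CC(=O)O` differ only in the aromatic group at the far end of the chain. In a functional assay on CHO-K1 cells for antagonist activity at cysteinyl leukotriene receptor 1 (Homo sapiens), read by fluorescence and calcium flux, with stated times of 30 min and 1 h (a lower number here means a stronger inhibitor, a higher number a weaker inhibitor), compound 1 gives 1.1 nM, and compound 2 gives 0.8 nM, the two values sitting within the scatter of each other, as the step of a 1.4-fold lower number from compound 1 to compound 2 (0.14 log units; within the scatter) shows. Compound 2 thus stands at one of two closely matched numbers. Compound 3 `Cc1c(CCCC(=O)O)c2cccc(/C=C/c3ccc(OCCCCc4c(F)ccc(F)c4F)cc3)c2n1CC(=O)O` has not been measured; it differs from compound 2 by 2,3,6-trifluorophenyl in place of 2,3,4,5-tetrafluorophenyl on a saturated chain carbon, four bonds along the chain from an oxygen on an aromatic ring. Going by the values given here, the one measured step that bears on it, a 1.4-fold lower number from compound 1 to compound 2 (0.14 log units; within the scatter), exchanged the whole aryl group at this same place without moving the value beyond the scatter. A smaller reshuffling of fluorine atoms is therefore expected to leave the number about where compound 2 sits, with no step beyond the scatter in this assay in either direction, so the expected step is a 1.5-fold higher number from compound 2 to compound 3 (0.18 log units; within the scatter). Compound 3 is estimated at 1.2 nM, with a likely range from 0.5 nM to 3 nM.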

Compound 3, half-maximal inhibitory concentration in the cysteinyl leukotriene receptor 1 assay: 2.4 nM
For compound 3 the middle estimate is 2.0-fold (0.30 log units) below the measured one; the measured number falls inside the stated range.
By their numbers in the cysteinyl leukotriene receptor 1 assay, from the lowest: compounds 2 and 1 (each within the scatter of the next); then compound 3.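

The aryl group at this position is less forgiving than the first pair suggested. In the cysteinyl leukotriene receptor 1 assay, 2,3,6-trifluorophenyl in place of 2,3,4,5-tetrafluorophenyl gives a 3.0-fold higher number from compound 2 to compound 3 (0.48 log units; beyond the scatter), and in place of 3-fluoro-2-methylphenyl it gives a 2.2-fold higher number from compound 1 to compound 3 (0.34 log units; beyond the scatter), so a change confined to this ring can move the number beyond the scatter, though both steps are modest. The same exchange also reveals a trade-off, with weaker inhibition accompanied by higher permeability in a physicochemical assay for permeability, using PAMPA, with a stated time of 4 h, at pH 6.2, tested at 50 uM; on this read-out lower numbers stand for lower permeability and higher numbers for higher permeability: the measured apparent permeability of compound 2, 1.8 10^-6 cm/s, and of compound 3, 4.4 10^-6 cm/s, a 2.4-fold higher number (0.39 log units; beyond the scatter). In the physicochemical assay compound 2 gives 1.8 10^-6 cm/s, and compound 3 gives 4.4 10^-6 cm/s.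

Compound 3 differs from compound 2 in both the number and the arrangement of its fluorine atoms, so the compounds shown cannot separate these two changes. They also leave open how an unsubstituted phenyl group or a 2,3,6-trichlorophenyl group at this place would behave on either read-out.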